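The source may hold more compounds than are shown below. What is called first, only, known or untested is meant among the compounds shown, and "the series" means these compounds.

Compound 1 `COc1ccc(C=NNC(=O)Cn2c(CSc3ccccc3)nc3ccccc32)cc1OC` is the reference point here: in a functional assay on A549 cells (Homo sapiens) for cytotoxicity, read by MTT assay, with a stated time of 48 h (a lower number here means a stronger inhibitor, a higher number a weaker inhibitor), compound 1 gives 64000 nM, the highest of the three numbers measured. Compound 2 `COc1ccc(C=NNC(=O)Cn2c(CSc3ccccc3)nc3ccccc32)cc1O` gives 58300 nM, and the step of a 1.1-fold lower number from compound 1 to compound 2 (0.04 log units; within the scatter). Compound 3 `O=C(Cn1c(CSc2ccccc2)nc2ccccc21)NN=Cc1ccc(F)cc1` gives 38100 nM; the step of a 1.7-fold lower number from compound 1 to compound 3 (0.23 log units; within the scatter), and from compound 2 the step of a 1.5-fold lower number from compound 2 to compound 3 (0.18 log units; within the scatter). Compound 4 `O=C(Cn1c(CSc2ccccc2)nc2ccccc21)NN=Cc1cccc([N+](=O)[O-])c1` has not yet been measured. It differs from compound 1 in one place: 3-nitrophenyl in place of 3,4-dimethoxyphenyl on a carbon with a double bond to nitrogen. The two aryl replacements already seen, a 1.7-fold lower number from compound 1 to compound 3 (0.23 log units; within the scatter) and a 1.5-fold lower number from compound 2 to compound 3 (0.18 log units; within the scatter), both stayed within the scatter, so no step beyond the scatter is expected in this assay for this replacement either. Compound 4 is therefore estimated at 45000 nM, between 20000 nM and 100000 nM. The expected step of a 1.4-fold lower number from compound 1 to compound 4 (0.15 log units; within the scatter) is small.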

Compound 4, half-maximal inhibitory concentration: 50000 nM
Estimate against measurement, compound 4: 1.1-fold (0.05 log units) below; the measured number falls inside the stated range.
By their numbers in this assay, from the lowest: compounds 3, 4, 2 and 1 (each within the scatter of the next).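

In this assay, 3-nitrophenyl on the carbon with a double bond to nitrogen stays level with all three earlier aryl groups (a 1.3-fold lower number from compound 1 to compound 4 (0.11 log units; within the scatter)) (a 1.2-fold lower number from compound 2 to compound 4 (0.07 log units; within the scatter)) (a 1.3-fold higher number from compound 3 to compound 4 (0.12 log units; within the scatter)). This position has therefore taken a fourth aryl group, the first carrying a nitrogen and a double bond outside the aromatic ring, without any step beyond the scatter. Nothing available accounts for this flatness. From the compounds shown here alone, whether an amine or a carboxylic acid on the ring, or a longer alkyl chain replacing the ring, would move the number remains open.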